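The source may hold more compounds than are shown below. What is called first, only, known or untested is meant among the compounds shown, and "the series" means these compounds.

Series notes. Compound 2 `C#Cc1cn([C@@H]2O[C@H](CO)[C@@H](O)[C@H]2O)c2ncnc(C)c12` carries ethynyl on its core; in an ADME assay on MRC5 cells (Homo sapiens), read by MTT assay, with a stated time of 72 h (on this read-out higher numbers stand for weaker inhibition and lower numbers for stronger inhibition), compound 2 gives 1440 nM. Compound 1 `Cc1ncnc2c1c(I)cn2[C@@H]1O[C@H](CO)[C@@H](O)[C@H]1O` differs from it by iodo in place of ethynyl on an aromatic carbon, and in this assay compound 1 gives 13300 nM, so that a 9.2-fold higher number from compound 2 to compound 1 (0.97 log units; beyond the scatter). Compound 3 `C#Cc1cn([C@@H]2O[C@H](CO)[C@@H](O)[C@H]2O)c2nc(C)nc(N)c12` has a different core; the difference between the cores of compound 2 and compound 3 is not broken down here. In this assay compound 3 gives > 100000 nM, which is a limit of the assay and not a number. Compound 3 thus sits at the limit of > 100000 nM in this assay, at which 1 of the 3 values shown sits. Compound 4 `Cc1nc(N)c2c(I)cn([C@@H]3O[C@H](CO)[C@@H](O)[C@H]3O)c2n1`, not yet measured, differs from compound 3 by iodo in place of ethynyl on an aromatic carbon, the same change as from compound 2 to compound 1, at a place described in the same words. In this assay a step that the limit leaves unreadable from compound 3 to compound 4 is expected, resting on a 9.2-fold higher number from compound 2 to compound 1 (0.97 log units; beyond the scatter) and on compound 3 already standing at a limit. Compound 4 is therefore estimated at 200000 nM, between 100000 nM and 800000 nM, and will most likely be reported only as a limit.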

Compound 4, half-maximal inhibitory concentration: 85800 nM
Beside the measured number, compound 4's estimate is 2.3-fold (0.37 log units) above it, and the stated range ends above it.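

In this assay, iodo in place of ethynyl on an aromatic carbon does not carry over from one core to the other as a step of one size: the same change on two cores in this assay, a 9.2-fold higher number (0.97 log units; beyond the scatter) from compound 2 to compound 1 and an at least 1.1-fold lower number (0.06 log units; that floor lies within the scatter) from compound 3 to compound 4, at least 10-fold (1.03 log units) apart, beyond the scatter of two such steps.

On the core of compound 3 the change gives an at least 1.1-fold lower number from compound 3 to compound 4 (0.06 log units; that floor lies within the scatter); this fixes only a floor, so neither the true size of the step nor a real fall beyond the scatter is shown.

Compound 3 stands at a limit and not at a number: the limit of > 100000 nM in this assay, at which 1 of the 4 values shown sits.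

Which part of the difference between the two cores goes with the different steps remains open. Also open, as far as these compounds go, is how bromo or nitrile, in place of ethynyl at this aromatic carbon, would read on either core.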